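From fluoro to chloro in a cell toxicity test

The source may hold more compounds than are shown below. What is called first, only, known or untested is meant among the compounds shown, and "the series" means these compounds.

In an ADME assay on Vero cells (Chlorocebus sabaeus) for cytotoxicity, read by MTT assay, with a stated time of 72 h (on this read-out higher numbers stand for lower toxicity in this test and lower numbers for higher toxicity in this test), compound 1 `CCOc1ccc(/C=C/C(=O)c2ccc3c(c2O)C=CC(C)(C)O3)cc1` gives 215000 nM and compound 2 `CC1(C)C=Cc2c(ccc(C(=O)/C=C/c3ccc(F)cc3)c2O)O1` gives 158000 nM. Among the compounds with values here, these two numbers lie within the usual scatter of each other, so compound 2 stands level with compound 1 on the only measurements available. Compound 3 `CC1(C)C=Cc2c(ccc(C(=O)/C=C/c3ccc(Cl)cc3)c2O)O1` keeps the core of compound 2 and changes one group: chloro in place of fluoro on an aromatic carbon, para to a large group. Within the data shown here, the one measured step that bears on this is a 1.4-fold lower number from compound 1 to compound 2 (0.13 log units; within the scatter), where fluoro took the place of ethoxy on an aromatic carbon. A single step is thin evidence, but it gives no reason to expect a change beyond the scatter in this assay. The expected step is a 1.1-fold lower number from compound 2 to compound 3 (0.02 log units; within the scatter). Compound 3 is estimated at 150000 nM, with an expected range from 75000 nM to 290000 nM.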

Compound 3, half-maximal cytotoxic concentration: 92200 nM
Compound 3: the middle estimate sits 1.6-fold (0.21 log units) above what was measured; low and high end bracket the measured number.
By their numbers in this assay, from the lowest: compounds 3, 2 and 1 (each within the scatter of the next, the first and the last beyond it).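

In this assay the swap of fluoro for chloro, on this aromatic carbon para to a large group, gives a 1.7-fold lower number from compound 2 to compound 3 (0.23 log units; within the scatter) and so does not clearly separate the two compounds. At the same place, chloro in place of ethoxy gives a 2.3-fold lower number from compound 1 to compound 3 (0.37 log units; beyond the scatter) and shows that the group held here can move the number beyond the scatter, if only modestly, even though compound 2 lies within the scatter of both neighbours. Nothing available explains either step.

The compounds shown carry only fluoro, chloro and ethoxy at this place, so how an amine, a carboxylic acid or a longer chain would read there stays open. Also open, from the compounds shown here alone, is whether the swap of fluoro for chloro would give a similar step on another core.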